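A few compounds are considered here, and "the series" means these few. Any claim that something is new, unique, unknown or untested is made for them only; others in the source may bear on it.

Compound 1 `CC(=O)NS(=O)(=O)c1ccc(N/C(S)=N\c2ccnc3cc(C(F)(F)F)ccc23)cc1` and compound 2 `O=S(=O)(Nc1ccccn1)c1ccc(N/C(S)=N\c2ccnc3cc(C(F)(F)F)ccc23)cc1` share one core and differ only in the group carried by the sulfonamide nitrogen. In a functional assay on HT-1080 cells (Homo sapiens) for antiproliferative activity, read by sulforhodamine B assay, with a stated time of 48 h (on this read-out higher numbers stand for weaker inhibition and lower numbers for stronger inhibition), compound 1 gives 28300 nM, and compound 2 gives 28000 nM. Compound 2 thus carries the lower of the two numbers, but its gap to compound 1 lies within the scatter, so the two compounds cannot be told apart on these data. Among the measured compounds shown here, the one step that bears on this position, a 1.0-fold lower number from compound 1 to compound 2 (0.00 log units; within the scatter), shows that exchanging an acetyl group for a pyridin-2-yl group on the sulfonamide nitrogen gave a number within the scatter. Compound 3 `COc1ncnc(NS(=O)(=O)c2ccc(N/C(S)=N\c3ccnc4cc(C(F)(F)F)ccc34)cc2)c1OC` carries the next variation at the same place: 5,6-dimethoxypyrimidin-4-yl in place of pyridin-2-yl on a sulfonamide nitrogen. For the measured compounds named here, because the only measured step at the sulfonamide nitrogen, a 1.0-fold lower number from compound 1 to compound 2 (0.00 log units; within the scatter), is flat, no step beyond the scatter is expected in this assay for this exchange either. The estimated step is no change at the digits printed from compound 2 to compound 3 (within the scatter). Compound 3 is therefore expected to give about 28000 nM, with a range from 12000 nM to 65000 nM.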

Compound 3, half-maximal inhibitory concentration: 22800 nM
Compound 3: the middle estimate sits 1.2-fold (0.09 log units) above what was measured; measured number inside the range.
By their numbers in this assay, from the lowest: compounds 3, 2 and 1 (each within the scatter of the next).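

In this assay, the step to the 5,6-dimethoxypyrimidin-4-yl group gives a 1.2-fold lower number from compound 2 to compound 3 (0.09 log units; within the scatter), and the comparison with the acetyl compound gives a 1.2-fold lower number from compound 1 to compound 3 (0.09 log units; within the scatter), so the three compounds cannot be told apart on these data. Until now, the flat result at the sulfonamide nitrogen rested on acetyl and pyridin-2-yl alone; it now also covers a group of 10 heavy atoms and 4 hydrogen-bond acceptors, against 6 heavy atoms and 1 hydrogen-bond acceptor for pyridin-2-yl, with no step beyond the scatter among the three compounds. No measurement is available that would explain this flat result.

From the compounds shown here alone, it remains open whether a group of another kind on the sulfonamide nitrogen, such as a plain hydrogen, a methyl group, or a longer chain ending in an amine or a carboxylic acid, would give a step beyond the scatter. Going by these compounds, it also remains open whether the same flat result would hold on a different core, since all three compounds share one.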